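Capping the Phenol of a Weakly Active Triazole Analogue

The compounds below may be only part of what the source reports. "The series", "measured", "known", "first", "only" and "open" are said of these compounds alone.

Of the compounds shown here, three sharing one core have been tested in a functional assay on MCF7 cells (Homo sapiens) for cytotoxicity, read by MTT assay, with a stated time of 4 days; a lower number here means a stronger inhibitor, a higher number a weaker inhibitor. Compound 1 `C=C1C(=O)[C@]23C[C@@]1(O)CC[C@H]2c1ccc(O)c(C)c1[C@@H]3Cn1cc(-c2ccc(C)cc2)nn1` gives 370 nM. Compound 2 `C=C1C(=O)[C@]23C[C@@]1(O)CC[C@H]2c1ccc(O)c(C)c1[C@@H]3Cn1cc(-c2ccc(Cl)cc2)nn1` gives 2470 nM, and compound 3 `C=C1C(=O)[C@]23C[C@@]1(O)CC[C@H]2c1ccc(O)c(C)c1[C@@H]3Cn1cc(-c2ccccc2)nn1` gives 1740 nM. Compound 2 sits far from compound 1, with a 6.7-fold higher number from compound 1 to compound 2 (0.82 log units; beyond the scatter), while its distance to compound 3 is small, a 1.4-fold lower number from compound 2 to compound 3 (0.15 log units; within the scatter); the step of a 4.7-fold higher number from compound 1 to compound 3 (0.67 log units; beyond the scatter) separates those two. All three steps concern the group on the phenyl ring attached to the triazole.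

Compound 4 `C=C1C(=O)[C@]23C[C@@]1(O)CC[C@H]2c1ccc(OS(=O)(=O)c2ccc(C)cc2)c(C)c1[C@@H]3Cn1cc(-c2ccc(Cl)cc2)nn1` differs from compound 2 elsewhere: (4-methylphenyl)sulfonyl in place of hydrogen on an oxygen on an aromatic ring. Within the data shown here, none of the measured steps touches this oxygen, so no step bears directly on the change; the data give no guide to its direction. With nothing to anchor a shift, the expectation for compound 4 is a step no larger than a 1.2-fold higher number from compound 2 to compound 4 (0.08 log units; within the scatter) in this assay, near the value of compound 2 2470 nM. Compound 4 is therefore estimated at 3000 nM, within the range 700 nM to 13000 nM.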

Compound 4, half-maximal inhibitory concentration: 1440 nM
The estimate for compound 4 lay 2.1-fold (0.32 log units) above the measured number; measured number inside the range.
By their numbers in this assay, from the lowest: compound 1; then compounds 4, 3 and 2 (each within the scatter of the next).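

In this assay, putting (4-methylphenyl)sulfonyl in place of hydrogen on the oxygen gives a 1.7-fold lower number from compound 2 to compound 4 (0.23 log units; within the scatter) and so leaves compound 4 indistinguishable from compound 2. The earlier compounds shown here varied only the phenyl ring attached to the triazole, whereas this result shows that, with the chloro group present on that ring, the free hydroxy on the shared core can be replaced by ((4-methylphenyl)sulfonyl)oxy without a step beyond the scatter. Nothing measured here explains why the cytotoxicity stays at this level.

The compounds shown leave open whether other groups on this oxygen, such as a methyl, an acetyl or a longer chain ending in an amine, would also stay close to compound 2. Among these compounds, they also leave open whether the same change would hold up on compound 1, the one compound that stands apart from compound 2.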